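The source may report more compounds than this note shows. Statements on the series, on what has been measured and on what is new or still open speak of the compounds shown alone.

Measured in a functional assay on HT-29 cells (Homo sapiens) for cytotoxicity, read by MTT assay, with a stated time of 72 h; a lower number here means a stronger inhibitor, a higher number a weaker inhibitor:

Compound 1 `N[C@H]1CC[C@H](Nc2c(C(=O)NCc3ccc(F)cc3)nc(N3CCCCS3(=O)=O)c3cccnc23)CC1`: > 10000 nM
Compound 2 `CC(C)(C)OC(=O)N1CCN(c2c(C(=O)NCc3ccc(F)cc3)nc(Br)c3cccnc23)CC1`: > 10000 nM
Compound 3 `N[C@H]1CC[C@H](Nc2c(C(=O)NCc3ccc(F)cc3)nc(N3CCCCC3)c3cccnc23)CC1`: "not determined" (no result reported)

Compound 2 gives > 10000 nM in this assay, and this is a limit of the assay, not a number. Compound 1 gives > 10000 nM, which is likewise a limit. Compound 3 has no result to set beside them, so the series offers only (the limit of > 10000 nM in this assay, at which 2 of the 3 values shown sit). Compound 2 therefore stands at that limit, and how far beyond it the true value lies is not known.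

The next compound to be tested is compound 4 `O=C(NCc1ccc(F)cc1)c1nc(Br)c2cccnc2c1N1CCNCC1`. It is compound 2 with hydrogen in place of tert-butoxycarbonyl on an amine nitrogen in a ring. Within the data shown here, no pair of measured compounds shows what this change does in this assay, so neither the size nor the direction of a step can be read from the data. The expectation is therefore for no step beyond the scatter, with compound 4 staying close to the limit, and a report of the limit alone is more likely than a number. The expected change is a number no higher from compound 2 to compound 4 (the limit leaves the size open). For compound 4 the estimated value is 10000 nM, with an expected range from 3000 nM to 30000 nM.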

Compound 4, half-maximal inhibitory concentration: 10000 nM
Estimate against measurement, compound 4: no gap at the digits printed, within the range that was stated.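

In this assay, putting hydrogen in place of tert-butoxycarbonyl on the amine nitrogen in the ring gives a number no higher from compound 2 to compound 4 (the limit leaves the size open). Compound 2 gives > 10000 nM, and this is a limit of the assay, not a number. Among these compounds, compound 4 gives 10000 nM, the only actual number so far, so this position now has one value that can serve as a reference for later changes. The series as a whole remains tied to a single limit: the limit of > 10000 nM in this assay, at which 2 of the 4 values shown sit.

On these data alone, how far the value moved with this change stays unknown, and so does whether the tert-butoxycarbonyl group itself matters or any other group at that nitrogen would serve equally. The compounds shown leave open what a methyl group, an acetyl group or a longer chain ending in a carboxylic acid on the same amine nitrogen would do in this assay, and whether the number seen for compound 4 would hold with a different group in place of the bromine.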